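Three inactive amides and a switch to 2-methylphenyl

The compounds below may be only part of what the source reports. "The series", "measured", "known", "first", "only" and "open" are said of these compounds alone.

Compound 3 `O=C(/C=C/c1coc2cc(O)ccc2c1=O)NCc1ccc(F)cc1` is known only by a limit: in a functional assay on HeLa cells (Homo sapiens) for inhibition, read by MTT assay, with a stated time of 48 h (a higher number here means a weaker inhibitor, a lower number a stronger inhibitor), compound 3 gives > 100000 nM, which is the limit of the assay and not a number. Compound 1 `COc1ccc(CNC(=O)/C=C/c2coc3cc(O)ccc3c2=O)cc1` likewise gives a limit, > 100000 nM in this assay. Compound 2 `COc1ccc2c(=O)c(/C=C/C(=O)NCc3ccc(F)cc3)coc2c1` also gives a limit, > 100000 nM in this assay. The steps a step that the two limits leave unreadable from compound 1 to compound 3 and a step that the two limits leave unreadable from compound 2 to compound 3 are therefore both unreadable, as the limit of > 100000 nM in this assay, at which 3 of the 3 values shown sit, shows. Compound 4 `Cc1ccccc1NC(=O)/C=C/c1coc2cc(O)ccc2c1=O` differs from compound 3 by 2-methylphenyl in place of 4-fluorobenzyl on an amide-type nitrogen. Within the data shown here, no measured step bears on this change, and every known value sits at the limit, so compound 3 gives no direction to read. For compound 4 the expected step from compound 3 is a step that the limit leaves unreadable from compound 3 to compound 4, most likely again a limit. Compound 4 is estimated at 150000 nM, within 40000 nM to 600000 nM.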

Compound 4, half-maximal inhibitory concentration: 8670 nM
Compound 4: middle estimate off by 17-fold (1.24 log units), on the high side; measured number outside the range, below it.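

In this assay, among these compounds, 2-methylphenyl in place of 4-fluorobenzyl on the amide-type nitrogen gives an at least 11-fold lower number from compound 3 to compound 4 (1.06 log units; beyond the scatter), so this position, unlike the two places changed among the earlier compounds, yields a readable value. The change moves the read-out off the limit, and the true size of the step stays unknown because compound 3 has only a limit: the limit of > 100000 nM in this assay, at which 3 of the 4 values shown sit.

The compounds shown leave open whether the methyl group or the direct attachment of the aromatic ring to the nitrogen accounts for the step. Phenyl or 2-chlorophenyl on the same nitrogen would help to separate the two.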